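Changing the aryl group on the urea nitrogen

The source may report more compounds than this note shows. Statements on the series, on what has been measured and on what is new or still open speak of the compounds shown alone.

Compound 1 `O=C(Nc1cccc(C(F)(F)F)c1)N[C@H]1CC[C@H](Oc2ccc(C(F)(F)F)cc2)CC1`: 460 nM
Compound 2 `O=C(Nc1ccc(Cl)cc1)N[C@H]1CC[C@H](Oc2ccc(F)cc2)CC1`: > 20000 nM

In a functional assay on CRL2813 cells (Homo sapiens) for cytotoxicity, read by sulforhodamine B assay, with a stated time of 5 days (on this read-out lower numbers stand for stronger inhibition and higher numbers for weaker inhibition), compound 1 gives 460 nM. For compound 2 this assay reports only a limit, > 20000 nM, which marks the edge of what the assay can measure rather than a number. Compound 2 therefore stands at the limit of > 20000 nM in this assay, at which 1 of the 2 values shown sits.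

Compound 3 `O=C(Nc1ccccc1F)N[C@H]1CC[C@H](Oc2ccc(F)cc2)CC1` differs from compound 2 in one place: 2-fluorophenyl in place of 4-chlorophenyl on an amide-type nitrogen. Among the compounds with values here, no pair of measured compounds shows the effect of such a change, so nothing in the measured values tells how large a step to expect. Since compound 2 sits at the limit of this assay, compound 3 can only be placed by expectation, and the most cautious expectation is that the step from compound 2 to compound 3 stays within the scatter: a number no higher from compound 2 to compound 3 (the limit leaves the size open). Compound 3 is accordingly estimated at 20000 nM, with a likely range from 5000 nM to 60000 nM, and a considerable chance that this assay again returns only a limit for compound 3.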

Compound 3, half-maximal inhibitory concentration: 17500 nM
Estimate against measurement, compound 3: 1.1-fold (0.06 log units) above; the measured number falls inside the stated range.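

In this assay, within the data shown here, the change from 4-chlorophenyl to 2-fluorophenyl on an amide-type nitrogen replaces an open-ended reading with an actual number, giving the first measured value for a compound with this 4-fluorophenyl ether side. For compound 2, the assay gives only a limit, > 20000 nM. The change can therefore be read only as a floor, an at least 1.1-fold lower number from compound 2 to compound 3 (0.05 log units; that floor lies within the scatter), and its true size stays unknown, with the limit setting how little can be said: the limit of > 20000 nM in this assay, at which 1 of the 3 values shown sits.

On these data alone, both the halogen and its place on the ring change in this single swap, so their separate contributions remain open, and 2-chlorophenyl or 4-fluorophenyl on the same nitrogen would be needed to pull them apart. Also open, as far as these compounds go, is how the value of compound 3 would move if the 2-fluorophenyl gave way to the trifluoromethyl-bearing aryl group of compound 1 while the rest of compound 3 stayed the same, or to a ring carrying a carboxylic acid or an amine.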